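From 4-nitrophenyl to 3-nitrophenyl: an expected small step

The source may hold more compounds than are shown below. What is called first, only, known or untested is meant among the compounds shown, and "the series" means these compounds.

Compound 1 `O=C(O)c1ccccc1COc1ccc(OCCOCCNC2CCCC2)cc1` gives > 100000 nM as a limit
Compound 2 `O=[N+]([O-])c1ccc(COc2ccc(OCCOCCNC3CCCC3)cc2)cc1` gives 20300 nM as a number

Among the compounds with values here, in a functional assay on SK-OV-3 cells (Homo sapiens) for inhibition, read by CCK-8 assay, with a stated time of 70 h (a higher number here means a weaker inhibitor, a lower number a stronger inhibitor), compound 2 gives 20300 nM as the only true number so far. Compound 1 gives > 100000 nM as a limit of the assay, not a number.

Compound 3 `O=[N+]([O-])c1cccc(COc2ccc(OCCOCCNC3CCCC3)cc2)c1` has the same atoms as compound 2, joined differently. The difference (3-nitrophenyl in place of 4-nitrophenyl on a saturated chain carbon bound to an oxygen on an aromatic ring) lies on a saturated chain carbon bound to an oxygen on an aromatic ring. Within the data shown here, the one measured step at this place (an at least 4.9-fold lower number from compound 1 to compound 2 (0.69 log units; beyond the scatter)) is beyond the scatter, but it replaced 2-carboxyphenyl with 4-nitrophenyl and starts from a limit (the limit of > 100000 nM in this assay, at which 1 of the 2 values shown sits). Among the measured compounds shown here, no measured step shows what 3-nitrophenyl in place of 4-nitrophenyl does. In this assay no step beyond the scatter is therefore expected, and the estimate stays close to compound 2 (20300 nM) with a wide range.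

The estimated step (a 1.0-fold lower number from compound 2 to compound 3 (0.01 log units; within the scatter)) is expected to stay within the scatter. Compound 3 is estimated at 20000 nM with an expected range (8000 nM to 50000 nM).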

Compound 3, half-maximal inhibitory concentration: 15400 nM
The estimate for compound 3 lay 1.3-fold (0.11 log units) above the measured number, and the stated range covers the measured number.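

In this assay, 3-nitrophenyl in place of 4-nitrophenyl gives a 1.3-fold lower number from compound 2 to compound 3 (0.12 log units; within the scatter), so at this place on a saturated chain carbon bound to an oxygen on an aromatic ring, the data do not separate the two nitrophenyl groups. 3-Nitrophenyl in place of 2-carboxyphenyl gives an at least 6.4-fold lower number from compound 1 to compound 3 (0.81 log units; beyond the scatter), which shows that the lower number relative to compound 1 is not confined to 4-nitrophenyl, as compound 2 alone could not show. This second step starts from a limit of the assay held by compound 1, and its full size cannot be read: the limit of > 100000 nM in this assay, at which 1 of the 3 values shown sits.

The compounds shown leave open whether the weak result for compound 1 follows from the carboxylic acid itself or from where it sits, a question that 2-nitrophenyl or 4-carboxyphenyl would help to settle, and whether a plain phenyl or an aminophenyl would match the nitrophenyl compounds. Going by these compounds, the rest of the molecule is the same in all three compounds, so what a longer chain would do also stays open.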